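Shortening the nonyl chain of compound 2 to methyl

The source may hold more compounds than are shown below. What is called first, only, known or untested is meant among the compounds shown, and "the series" means these compounds.

compound 1 `CCCC=Cc1cc(-c2ccc3cc(C(=O)O)ccc3c2)ccc1O` gives 5.38 ug/mL
compound 2 `CCCCCCCCCc1cc(-c2ccc3cc(C(=O)O)ccc3c2)ccc1O` gives 1.73 ug/mL
compound 3 `CCCCCC=Cc1cc(-c2ccc3cc(CO)ccc3c2)ccc1O` gives 4.19 ug/mL

In a functional assay on HepG2 cells (Homo sapiens) for cytotoxicity, read by WST assay, with a stated time of 24 h (a higher number here means that more compound is tolerated, a lower number that less compound is tolerated), compound 2 has the lowest number of the three, with compound 3 the nearest and compound 1 the furthest above it.

The next case is compound 4 `Cc1cc(-c2ccc3cc(C(=O)O)ccc3c2)ccc1O` and its difference from compound 2 is hydrogen in place of octyl on a saturated chain carbon bound to an aromatic carbon in a single change, which can also be read as nonyl to methyl. Among the measured compounds shown here, one measured step bears on this: putting nonyl in place of pent-1-en-1-yl gave a 3.1-fold lower number from compound 1 to compound 2 (0.49 log units; beyond the scatter) as a modest move. The change to compound 4 runs the opposite way, from nonyl to a much shorter group. On the strength of a 3.1-fold lower number from compound 1 to compound 2 (0.49 log units; beyond the scatter) alone, a higher number is expected, and somewhat more of a move than that step, since more of the chain goes. This remains an extrapolation from one pair. For the measured compounds named here, no measured compound carries a chain as short as methyl, and that pair also differs by a double bond. The expected change is a 5.2-fold higher number from compound 2 to compound 4 (0.72 log units; beyond the scatter) on this reasoning. For compound 4 the estimated value is 9 ug/mL with an expected range from 3.5 ug/mL to 25 ug/mL in this test.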

Compound 4, concentration lethal to 50% of the cells: > 32 ug/mL
Compound 4 gave a limit, no number; the forecaster's own chance of this, stated with the estimate: 10%; at least 3.5-fold (0.55 log units) between middle value and limit.
By their numbers in this assay, from the lowest: compound 2; then compounds 3 and 1 (each within the scatter of the next). At a limit, above all of these: compound 4.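

In this assay compound 4 gives > 32 ug/mL, which is a limit of the assay and not a number. Cutting the nonyl chain back to methyl gives an at least 18-fold higher number from compound 2 to compound 4 (1.26 log units; beyond the scatter), and methyl in place of pent-1-en-1-yl gives an at least 5.9-fold higher number from compound 1 to compound 4 (0.77 log units; beyond the scatter), so the methyl compound stands apart from both longer-chain compounds, not only from the one with the longest chain. The earlier pair showed only a modest shift from changing the group on this aromatic carbon, whereas these steps show that it can move the number much further, although their full size stays unknown: the limit of > 32 ug/mL in this assay, at which 1 of the 4 values shown sits.

The compounds shown leave open how the number changes from methyl up to five carbons, which an ethyl or a propyl chain in this place would help to settle. They also leave open how much of the step from compound 1 to compound 2 comes from chain length and how much from the double bond, a question that a saturated pentyl chain in the same place would address.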